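This account rests on a few compounds, and the source may have more. Where it says the series, first, only, none or still open, it means among the compounds named here.

Measured compounds in a functional assay on DU-145 cells (Homo sapiens) for antiproliferative activity, read by propidium iodide staining, with a stated time of 96 h; a higher number here means a weaker inhibitor, a lower number a stronger inhibitor:
compound 1 `CC(O)(COc1ccc(C#N)cc1)C(=O)Nc1ccc(S(F)(F)(F)(F)F)cc1` gives 32200 nM;
compound 2 `CC(O)(COc1ccc(C#N)cc1C(F)(F)F)C(=O)Nc1ccc(S(F)(F)(F)(F)F)cc1` gives 21200 nM;
compound 3 `CC(O)(COc1ccc(C#N)cc1)C(=O)Nc1cccc(S(F)(F)(F)(F)F)c1` gives 42600 nM.

Compound 2 differs from compound 1 by trifluoromethyl in place of hydrogen on an aromatic carbon, and that change made a 1.5-fold lower number from compound 1 to compound 2 (0.18 log units; within the scatter). Compound 3 has the same atoms as compound 1 joined differently; the difference between the two cores is not broken down here. Compound 3 gives the highest of the three numbers, but its gaps to compound 1 and to compound 2 are both within the scatter, so no ordering among them is claimed.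

Compound 4 `CC(O)(COc1ccc(C#N)cc1C(F)(F)F)C(=O)Nc1cccc(S(F)(F)(F)(F)F)c1` has not yet been measured. It differs from compound 3 by trifluoromethyl in place of hydrogen on an aromatic carbon, the same change already seen from compound 1 to compound 2. In this assay compound 4 is expected to move by a 1.5-fold lower number from compound 3 to compound 4 (0.18 log units; within the scatter), a step about the size of the earlier one, because a 1.5-fold lower number from compound 1 to compound 2 (0.18 log units; within the scatter) shows what this change did once. The estimate for compound 4 is 28000 nM, expected to lie between 12000 nM and 65000 nM.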

Compound 4, half-maximal inhibitory concentration: 22800 nM
Compound 4: middle estimate off by 1.2-fold (0.09 log units), on the high side; the range from low to high includes it.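

In this assay, trifluoromethyl in place of hydrogen on an aromatic carbon gave a 1.9-fold lower number from compound 3 to compound 4 (0.27 log units; within the scatter), and the two steps for this change can be set side by side: the same change on two cores in this assay, a 1.5-fold lower number (0.18 log units; within the scatter) from compound 1 to compound 2 and a 1.9-fold lower number (0.27 log units; within the scatter) from compound 3 to compound 4, 1.2-fold (0.09 log units) apart, within the scatter of two such steps. On these two cores, then, the change carried over with a similar size, but each step lies within the scatter on its own, so neither shows that the change itself alters the number. Two cores also say nothing about how the change would carry to any other core.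

The compounds shown leave open whether a chlorine, a methoxy group or a nitro group on that aromatic carbon would give a step beyond the scatter. They also leave open what an amine or a carboxylic acid in place of the cyano group would do.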